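Bromo to Benzyloxy: Expected Cytotoxicity of Compound 4

The source may hold more compounds than are shown below. What is called first, only, known or untested is meant among the compounds shown, and "the series" means these compounds.

Measured compounds:
compound 1 `Cc1cc(O)c(C(=O)/C=C/c2ccccc2)c(-c2ccc(Br)cc2)c1C(=O)/C=C/c1ccccc1` – 30000 nM
compound 2 `Cc1cc(O)c(C(=O)/C=C/c2ccc3ccccc3c2)c(-c2ccc(Cl)cc2)c1C(=O)/C=C/c1ccc2ccccc2c1` – "not active" (no number reported)
compound 3 `Cc1cc(O)c(C(=O)/C=C/c2ccc3ccccc3c2)c(-c2ccccc2)c1C(=O)/C=C/c1ccc2ccccc2c1` – "not active" (no number reported)

Among the compounds with values here, in a functional assay on HeLa cells (Homo sapiens) for cytotoxicity, read by MTT assay, with a stated time of 24 h (a lower number here means a stronger inhibitor, a higher number a weaker inhibitor), compound 1 gives 30000 nM and is the only compound with a number. Compound 2 gives "not active" (no number reported) and compound 3 gives "not active" (no number reported), each without a reported number. Compound 4 `Cc1cc(O)c(C(=O)/C=C/c2ccccc2)c(-c2ccc(OCc3ccccc3)cc2)c1C(=O)/C=C/c1ccccc1` differs from compound 1 in a single place: benzyloxy in place of bromo on an aromatic carbon. Within the data shown here, no step between two measured compounds is available, so the effect of such a change cannot be read from the data. With compound 1 at 30000 nM and the other two compounds reporting no number, compound 4 is expected to stay in the same weak region. The step of no change at the digits printed from compound 1 to compound 4 (within the scatter) is expected to lie within the usual scatter. Compound 4 is therefore estimated at 30000 nM, in the range 10000 nM to 100000 nM.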

Compound 4, half-maximal inhibitory concentration: "not active" (no number reported)
Compound 4 has no reported number here, and the estimate cannot be compared.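

In this assay, within the data shown here, compound 4 is reported as not active without a number, so no step from compound 1 to compound 4 can be read. Nothing measured here bears on this result. The compounds shown leave open what size of change benzyloxy in place of bromo brings.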